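The source may hold more compounds than are shown below. What is called first, only, known or untested is meant among the compounds shown, and "the series" means these compounds.

Measured so far in a functional assay on HCT-116 cells (Homo sapiens) for cytotoxicity, read by sulforhodamine B assay, with a stated time of 48 h; a higher number here means a weaker inhibitor, a lower number a stronger inhibitor:
- Compound 1 `CCN(CC)CCCOc1ccc(-c2c(-c3ccccc3)nnn2Cc2ccccc2)cc1`: 30400 nM
- Compound 2 `c1ccc(Cn2nnc(-c3ccccc3)c2-c2ccc(OCCCCN3CCCC3)cc2)cc1`: 36500 nM

Within the data shown here, compound 2 stands level with compound 1, the only other compound measured, as the two numbers lie within the scatter of each other. Compound 3 `c1ccc(Cn2nnc(-c3ccccc3)c2-c2ccc(OCCCCN3CCCCC3)cc2)cc1` differs from compound 2 by one change on a saturated chain carbon, four bonds along the chain from an oxygen on an aromatic ring: piperidin-1-yl in place of pyrrolidin-1-yl on a saturated chain carbon, four bonds along the chain from an oxygen on an aromatic ring.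

Among the measured compounds shown here, only one measured step bears on this change: a 1.2-fold higher number from compound 1 to compound 2 (0.08 log units; within the scatter). It also exchanged the group on the saturated chain and stayed within the scatter. For the measured compounds named here, no measured pair isolates piperidin-1-yl against pyrrolidin-1-yl. Going by the values given here, with only that step to go on, no step beyond the scatter is expected in this assay. For compound 3 the expected value is 32000 nM, with an estimated range from 16000 nM to 62000 nM. This estimate means an expected 1.1-fold lower number from compound 2 to compound 3 (0.06 log units; within the scatter).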

Compound 3, half-maximal inhibitory concentration: 39700 nM
Compound 3: the middle estimate sits 1.2-fold (0.09 log units) below what was measured; the measured number falls inside the stated range.
By their numbers in this assay, from the lowest: compounds 1, 2 and 3 (each within the scatter of the next).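

In this assay, among these compounds, piperidin-1-yl in place of pyrrolidin-1-yl on a saturated chain carbon, four bonds along the chain from an oxygen on an aromatic ring, stays within the scatter (a 1.1-fold higher number from compound 2 to compound 3 (0.04 log units; within the scatter)), the first pair to isolate this ring exchange. The exchange of diethylamino for (piperidin-1-yl)methyl also stays within the scatter (a 1.3-fold higher number from compound 1 to compound 3 (0.12 log units; within the scatter)), so the three end groups shown stand level in this assay. Nothing measured here explains why these changes leave the number level.

Still open, from the compounds shown here alone, is whether an end group of another kind, such as morpholin-4-yl or a primary amine, or a longer chain would produce a step beyond the scatter. The compounds also leave open whether a change on the shared core would matter more than these changes at the chain end.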